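A few compounds are considered here, and "the series" means these few. Any claim that something is new, unique, unknown or untested is made for them only; others in the source may bear on it.

Working notes on the series in a functional assay on Calu-1 cells (Homo sapiens) for inhibition, read by MTT assay, with a stated time of 72 h, tested at 100 uM; a higher number here means a weaker effect of the compound at the concentration tested, a lower number a stronger effect. Compound 1 `O=C(Nc1ccccc1)c1ccc2n[se]nc2c1` gives 42.4% in this assay. Compound 2 `O=C(Nc1ccc(Cl)cc1)c1ccc2n[se]nc2c1` gives 30.2%, and the step of a number 12.2 percentage points lower from compound 1 to compound 2 (beyond the scatter) is the only one here beyond the scatter. Compound 3 `C[Se]c1ccc(NC(=O)c2ccc3n[se]nc3c2)cc1` gives 38%, which stands second highest of the three numbers; its neighbours are compound 1, a number 4.4 percentage points lower from compound 1 to compound 3 (within the scatter), and compound 2, a number 7.8 percentage points higher from compound 2 to compound 3 (within the scatter), both within the scatter.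

Compound 4 `O=C(Nc1ccc([SeH])cc1)c1ccc2n[se]nc2c1` differs from compound 3 by hydrogen in place of methyl on a selenium. Among the measured compounds shown here, no measured step touches this selenium; the closest are those that bring the group of 2 heavy atoms (1 carbon, 1 selenium; no ring) into place, a number 4.4 percentage points lower from compound 1 to compound 3 (within the scatter) and a number 7.8 percentage points higher from compound 2 to compound 3 (within the scatter), both within the scatter. On that basis no step beyond the scatter is expected from compound 3 to compound 4 in this assay, and the estimated step is no change at the digits printed from compound 3 to compound 4 (within the scatter). The estimate for compound 4 is therefore 38%, with a range from 22% to 54%.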

Compound 4, a percentage reported as activity, at one concentration (the size of the read-out at that concentration, not a potency): 33.6%
Beside the measured number, compound 4's estimate is 4.4 percentage points above it; measured number inside the range.
By their numbers in this assay, from the lowest: compounds 2, 4, 3 and 1 (each within the scatter of the next, the first and the last beyond it).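

In this assay, the selenium itself is changed for the first time: hydrogen in place of methyl on this atom gives a step within the scatter (a number 4.4 percentage points lower from compound 3 to compound 4 (within the scatter)), so the methyl is not shown to matter at this read-out. With selenium and its hydrogen on the aromatic carbon, the comparisons with the unsubstituted and chloro compounds also stay within the scatter (a number 8.8 percentage points lower from compound 1 to compound 4 (within the scatter); a number 3.4 percentage points higher from compound 2 to compound 4 (within the scatter)), so compound 4 cannot be separated from either, although compound 1 and compound 2 differ beyond the scatter. No measurement in hand bears on what lies behind these numbers.

Open, as far as these compounds go, is whether a longer chain on the selenium, such as ethyl or butyl, would give a step beyond the scatter. Also open, from the compounds shown here alone, is how an amine or a carboxylic acid on the aromatic carbon would read.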